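Alkyne aryl swap on the shared cyclohexyl core

A few compounds are considered here, and "the series" means these few. Any claim that something is new, unique, unknown or untested is made for them only; others in the source may bear on it.

Compound 3 `O=C1c2ccc(C#Cc3cccnc3)nc2CCN1C1CCCCC1` gives 15600 nM in an assay on HEK293 cells for displacement of a labelled ligand from metabotropic glutamate receptor 5 (Homo sapiens), with a stated time of 2 h (a lower number here means a stronger inhibitor, a higher number a weaker inhibitor), the higher of the two numbers in the series. Compound 1 `CC(C)N1CCc2nc(C#Cc3cccs3)ccc2C1=O` sits lower in this assay at 1930 nM. For compound 2 `Cc1ccccc1C#Cc1ccc2c(n1)CCN(C1CCCCC1)C2=O` this assay reports only a limit, > 32000 nM. Among the measured compounds shown here, the one measured step, an at least 2.0-fold lower number from compound 2 to compound 3 (0.31 log units; beyond the scatter), is an aryl swap on the shared core; its size is bounded by the limit of > 32000 nM in this assay, at which 1 of the 3 values shown sits. The step to compound 4 `O=C1c2ccc(C#Cc3cccs3)nc2CCN1C1CCCCC1` is thiophen-2-yl in place of pyridin-3-yl on a triple-bonded carbon. For the measured compounds named here, compound 1 also carries thiophen-2-yl on a triple-bonded carbon but differs from compound 4 elsewhere, so no measured step covers the change directly. A modest move to a lower number is expected, a 2.6-fold lower number from compound 3 to compound 4 (0.41 log units; beyond the scatter). Compound 4 is therefore estimated at 6000 nM, within 1500 nM to 25000 nM.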

Compound 4, inhibition constant: 720 nM
Beside the measured number, compound 4's estimate is 8.3-fold (0.92 log units) above it, and the stated range ends above it.
By their numbers in this assay, from the lowest: compound 4; then compound 1; then compound 3. At a limit, above all of these: compound 2.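

On the triple-bonded carbon, the aryl group proves a much stronger lever than the earlier step could show: a 22-fold lower number from compound 3 to compound 4 (1.34 log units; beyond the scatter). Compound 2 is held only at a limit, so an at least 44-fold lower number from compound 2 to compound 4 (1.64 log units; beyond the scatter) is a bound and not a measured size: the limit of > 32000 nM in this assay, at which 1 of the 4 values shown sits.

Among the compounds shown here, with thiophen-2-yl held fixed, a 2.7-fold lower number from compound 1 to compound 4 (0.43 log units; beyond the scatter) gives a first reading at the amide-type nitrogen, and this step is modest.

On these data alone, it remains open whether furan-2-yl on the triple-bonded carbon would match thiophen-2-yl. Also open, as far as these compounds go, is whether a phenyl or a longer alkyl chain on the amide-type nitrogen would shift the number further.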